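This account rests on a few compounds, and the source may have more. Where it says the series, first, only, none or still open, it means among the compounds named here.

Compound 1 `Cc1cccc(N2C(=O)CSC2c2cccc(C(=O)NCCCCc3ccccc3)c2)c1`: 10000 nM
Compound 2 `Cc1ccnc(N2C(=O)CSC2c2cccc(C(=O)NCCCCn3cccn3)c2)c1`: 50000 nM
Compound 3 `O=C(NCCCCc1ccccc1)c1cccc(C2SCC(=O)N2c2cccc(F)c2)c1`: 10000 nM

In a physicochemical assay for solubility, read by turbidimetry, measured as kinetic solubility, at pH 7.4 (a lower number here means a less soluble compound, a higher number a more soluble compound), compound 1 gives 10000 nM and compound 3 gives 10000 nM. These two differ only by fluoro in place of methyl on an aromatic carbon, and the step of no change at the digits printed from compound 1 to compound 3 (within the scatter). Compound 2 gives 50000 nM, the highest of the three; how its core differs from that of compound 1 is not broken down here. Compound 4 `O=C(NCCCCn1cccn1)c1cccc(C2SCC(=O)N2c2cc(F)ccn2)c1` has not yet been measured. It differs from compound 2 by fluoro in place of methyl on an aromatic carbon, which is the same kind of change as that from compound 1 to compound 3, though here it sits on a six-membered aromatic ring with 1 nitrogen, opposite the ring nitrogen, rather than on a ring of carbon only. Because the step of no change at the digits printed from compound 1 to compound 3 (within the scatter), compound 4 is expected to stay close to compound 2, with an estimated step of no change at the digits printed from compound 2 to compound 4 (within the scatter). The estimate for compound 4 is 50000 nM, between 25000 nM and 100000 nM.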

Compound 4, solubility: 50000 nM
Compound 4: middle estimate and measured number agree at the digits printed, within the range that was stated.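

In this assay fluoro in place of methyl on an aromatic carbon gives no change at the digits printed from compound 1 to compound 3 (within the scatter) on a ring of carbon only, and no change at the digits printed from compound 2 to compound 4 (within the scatter) on a six-membered aromatic ring with 1 nitrogen. The change therefore carries from one core to the other without a visible shift in either pair, and no compound shown goes against this. Two pairs say nothing about other cores, however, and no measurement shown explains why the two steps match.

Going by these compounds, what an amine or a carboxylic acid would do in the place of methyl or fluoro stays open. On these data alone, compound 1 and compound 2 differ in more than one place, so the part each difference plays in their gap also stays open.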